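The source may report more compounds than this note shows. Statements on the series, on what has been measured and on what is new or still open speak of the compounds shown alone.

Measured in a functional assay on CCRF-CEM cells (Homo sapiens) for antiproliferative activity, with a stated time of 72 h; on this read-out lower numbers stand for stronger inhibition and higher numbers for weaker inhibition:
- compound 1 `OC[C@H]1O[C@@H](n2cnc3c(NCc4ccccc4F)ncnc32)[C@H](O)[C@@H]1O` gives 4600 nM
- compound 2 `OC[C@H]1O[C@@H](n2cnc3c(NCc4ccccc4Cl)ncnc32)[C@H](O)[C@@H]1O` gives 14500 nM
- compound 3 `OC[C@H]1O[C@@H](n2cnc3c(NCc4ccccc4Br)ncnc32)[C@H](O)[C@@H]1O` gives 12300 nM

Compound 3 sits at the weaker end of this small set. It cannot be told apart from its nearest neighbour (a 1.2-fold lower number from compound 2 to compound 3 (0.07 log units; within the scatter)), and it lies clearly away from the furthest one (a 2.7-fold higher number from compound 1 to compound 3 (0.43 log units; beyond the scatter)).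

The next compound is compound 4 `Cc1ccc(CNc2ncnc3c2ncn3[C@@H]2O[C@H](CO)[C@@H](O)[C@H]2O)cc1`, and the change is this: 4-methylphenyl in place of 2-bromophenyl on a saturated chain carbon bound to a nitrogen on an aromatic ring. In words, 4-methylphenyl stands in place of 2-bromophenyl on a saturated chain carbon bound to a nitrogen on an aromatic ring.

Going by the values given here, no measured step makes this exact change, since all of them only exchange fluoro, chloro and bromo on the aromatic ring. They still give a sense of scale, because the largest of them stays modest (a 3.2-fold higher number from compound 1 to compound 2 (0.50 log units; beyond the scatter)). A modest step at most is therefore expected in this assay, with no firm direction.

The expected step is small (a 1.4-fold lower number from compound 3 to compound 4 (0.14 log units; within the scatter)). The estimate for compound 4 is 9000 nM (expected range from 3000 nM to 25000 nM).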

Compound 4, half-maximal inhibitory concentration: > 166000 nM
Compound 4 gave a limit, no number (the forecaster's own chance of this, stated with the estimate: 10%); middle value at least 18-fold (1.26 log units) away from the limit.
By their numbers in this assay, from the lowest: compound 1; then compounds 3 and 2 (each within the scatter of the next). At a limit, above all of these: compound 4.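

In this assay, the exchanges among fluoro, chloro and bromo suggested a place that changes only modestly, but the first non-halogen group brings much larger steps (an at least 13-fold higher number from compound 3 to compound 4 (1.13 log units; beyond the scatter)) and (an at least 11-fold higher number from compound 2 to compound 4 (1.05 log units; beyond the scatter)) and (an at least 36-fold higher number from compound 1 to compound 4 (1.55 log units; beyond the scatter)). The result for compound 4 is a limit and not a number: (the limit of > 166000 nM in this assay, at which 1 of the 4 values shown sits). The 2-bromophenyl and 4-methylphenyl groups have the same heavy-atom count, so activity at this place is not set by that count alone.

This change replaces the halogen with methyl and also alters the ring position named in the group, so the compounds shown cannot separate the two effects. From the compounds shown here alone, how a plain phenyl, or a phenyl carrying a methoxy group or an amine, would behave also remains open.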